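A few compounds are considered here, and "the series" means these few. Any claim that something is new, unique, unknown or untested is made for them only; others in the source may bear on it.

Working notes on the series. In an ADME assay on S9 fraction from liver (Homo sapiens) for metabolic stability, with a stated time of 1 h (a higher number here means that more of the compound is left, a lower number that less of the compound is left), compound 1 `CO[C@H]1CC[C@@H](Nc2cc(NCc3cnccc3C(F)(F)F)ncc2C#N)CC1` gives 19% and compound 2 `N#Cc1cnc(NCc2cnccc2C(F)(F)F)cc1NC1CCOCC1` gives 91%. Among the measured compounds shown here, compound 2 therefore holds the higher of the two numbers so far, and the gap lies beyond the scatter.

The next structure is compound 3 `N#Cc1cnc(NCc2cnccc2C(F)(F)F)cc1N[C@H]1CC[C@@H](C(N)=O)CC1`, with this difference: 4-carbamoylcyclohexyl in place of oxan-4-yl on a nitrogen on an aromatic ring. For the measured compounds named here, only one measured step bears on it: a number 72 percentage points higher from compound 1 to compound 2 (beyond the scatter), a large step beyond the scatter, made at the same nitrogen. Going by the values given here, the data hold no measured compound with 4-carbamoylcyclohexyl, so that step gives a direction but no direct size. Among the compounds with values here, the one measured compound with a ring of carbon only at this place, compound 1 at 19%, points downward. A fall beyond the scatter is therefore expected in this assay, though a clearly smaller one than the measured step. The expected change is a number 21 percentage points lower from compound 2 to compound 3 (beyond the scatter). For compound 3 the estimated value is 70%, with an expected range of 42% to 93%.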

Compound 3, percent of the compound remaining: 90%
Estimate against measurement, compound 3: 20 percentage points below, and the stated range covers the measured number.
By their numbers in this assay, from the lowest: compound 1; then compounds 3 and 2 (each within the scatter of the next).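

In this assay a ring of carbon only on the nitrogen on the aromatic ring does not by itself go with a low number: 4-carbamoylcyclohexyl in place of oxan-4-yl gives a number 1 percentage points lower from compound 2 to compound 3 (within the scatter) and leaves compound 2 and compound 3 indistinguishable here. With the cyclohexyl ring kept, carbamoyl in place of methoxy on a saturated ring carbon gives a number 71 percentage points higher from compound 1 to compound 3 (beyond the scatter) as a large step, so among these compounds the low number goes with the methoxy-bearing ring of compound 1, not with the carbon-only ring as such. The data shown offer no measured explanation for this difference.

Still open, on these data alone, is whether another group on that saturated ring carbon, such as a hydroxyl, an amine or a carboxylic acid, would stay with compound 2 and compound 3 or fall towards compound 1. Also open, as far as these compounds go, is whether the same reading holds once the trifluoromethyl group on the shared core gives way to another group, such as a chlorine atom or a methyl group.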